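Furan-to-thiophene swap on two epoxide chalcone cores

A few compounds are considered here, and "the series" means these few. Any claim that something is new, unique, unknown or untested is made for them only; others in the source may bear on it.

Compound 1 `O=C(/C=C/c1ccco1)c1ccccc1OCC1CO1` carries a furan-2-yl group on the enone; in an assay for inhibition of DNA topoisomerase 1 (Homo sapiens), with a stated time of 30 min, tested at 100 uM (on this read-out higher numbers stand for a stronger effect at the one concentration tested and lower numbers for a weaker effect), compound 1 gives 36.8%. Compound 2 `O=C(/C=C/c1cccs1)c1ccccc1OCC1CO1` differs from it only by thiophen-2-yl in place of furan-2-yl on a double-bonded chain carbon bound to a double-bonded chain carbon and in this assay compound 2 gives 11.1%, the step being a number 25.7 percentage points lower from compound 1 to compound 2 (beyond the scatter). Compound 3 `O=C(/C=C/c1ccco1)c1ccc(OCC2CO2)cc1` has the same atoms as compound 1 joined differently; the difference between the two cores is not broken down here. In this assay compound 3 gives 36.8%, within the scatter of compound 1. Among the measured compounds shown here, compound 4 `O=C(/C=C/c1cccs1)c1ccc(OCC2CO2)cc1` is not yet measured; it differs from compound 3 by thiophen-2-yl in place of furan-2-yl on a double-bonded chain carbon bound to a double-bonded chain carbon, the same change at the same place as the one between compound 1 and compound 2. The step expected in this assay is a number 25.8 percentage points lower from compound 3 to compound 4 (beyond the scatter), resting on a number 25.7 percentage points lower from compound 1 to compound 2 (beyond the scatter) made on the other core. Compound 4 is therefore estimated at 11%, with a range from 0% to 25%.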

Compound 4, a percentage reported as inhibition, at one concentration (the size of the read-out at that concentration, not a potency): 0%
Estimate against measurement, compound 4: 11 percentage points above, within the range that was stated.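

In this assay thiophen-2-yl in place of furan-2-yl on a double-bonded chain carbon bound to a double-bonded chain carbon gives a number 36.8 percentage points lower from compound 3 to compound 4 (beyond the scatter) and so repeats the direction seen on the core of compound 1. The change carries from one core to the other, with no difference in step size beyond the scatter: the same change on two cores in this assay, a number 25.7 percentage points lower (beyond the scatter) from compound 1 to compound 2 and a number 36.8 percentage points lower (beyond the scatter) from compound 3 to compound 4, 11.1 percentage points apart, within the scatter of two such steps. Among the compounds shown here, this rests on only two pairs, each read at one concentration, so it shows neither a change in potency nor why the read-out falls.

Still open, as far as these compounds go, is how a phenyl group or an amine would read at the same place. Also open, from the compounds shown here alone, is whether the step holds on any third core.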